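Replacing cyclohexyl with thiophen-2-yl in a low-stability compound

The source may report more compounds than this note shows. Statements on the series, on what has been measured and on what is new or still open speak of the compounds shown alone.

Within the data shown here, in an ADME assay on cells (Hepatocyte, Mus musculus) for metabolic stability, with a stated time of 30 min (on this read-out higher numbers stand for a more stable compound and lower numbers for a less stable compound), compound 1 (`CS(=O)(=O)NC1CCC(CN2CCN(c3cc(=O)c4cc(C(F)(F)F)cc([N+](=O)[O-])c4s3)CC2)CC1`) gives 111%, while compound 2 (`O=C(OC1CCC(CN2CCN(c3cc(=O)c4cc(C(F)(F)F)cc([N+](=O)[O-])c4s3)CC2)CC1)C1CCCCC1`) gives 1.2%, the lower of the two numbers so far. Among the measured compounds shown here, the only measured step, a number 109.8 percentage points lower from compound 1 to compound 2 (beyond the scatter), is large and beyond the scatter. It places (cyclohexylcarbonyl)oxy where methanesulfonamido stood on a saturated ring carbon. Compound 3 (`O=C(OC1CCC(CN2CCN(c3cc(=O)c4cc(C(F)(F)F)cc([N+](=O)[O-])c4s3)CC2)CC1)c1cccs1`) changes compound 2 in one place: thiophen-2-yl in place of cyclohexyl on a carbonyl carbon. Thiophen-2-yl thus stands in place of cyclohexyl on a carbonyl carbon, and the carbonyl and its oxygen remain. For the measured compounds named here, no measured step covers this swap, so the evidence is indirect. Compound 3 still lacks methanesulfonamido, the group that compound 1 carries at 111%, and it stays closer in structure to compound 2 at 1.2%. The expected change, a number 1.8 percentage points higher from compound 2 to compound 3 (within the scatter), is small and within the scatter. For compound 3 the estimate is 3%, with an expected range from 0.5% to 15%.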

Compound 3, percent of the compound remaining: 1.8%
The estimate for compound 3 lay 1.2 percentage points above the measured number, and the stated range covers the measured number.
By their numbers in this assay, from the lowest: compounds 2 and 3 (each within the scatter of the next); then compound 1.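

In this assay, thiophen-2-yl on the carbonyl carbon gives a number 0.6 percentage points higher from compound 2 to compound 3 (within the scatter), so exchanging this saturated carbon ring for a five-membered aromatic ring with sulfur does not separate the two compounds. Set against methanesulfonamido on the saturated ring carbon, ((thiophen-2-yl)carbonyl)oxy gives a number 109.2 percentage points lower from compound 1 to compound 3 (beyond the scatter), which means that a second group of the carbonyl-oxy type, with a different ring, also shows a large step from compound 1. Nothing measured here accounts for these numbers.

As far as these compounds go, it remains open whether the numbers would hold with an amide nitrogen in place of the oxygen next to the carbonyl group. From the compounds shown here alone, it is also open whether an amine or a carboxylic acid on the ring carried by the carbonyl carbon would shift the read-out beyond the scatter.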